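This account rests on a few compounds, and the source may have more. Where it says the series, first, only, none or still open, it means among the compounds named here.

Measured so far in an ADME assay on J774.A1 cells (Mus musculus) for cytotoxicity, read by MTT assay, with a stated time of 72 h; on this read-out higher numbers stand for lower toxicity in this test and lower numbers for higher toxicity in this test:
- compound 1 `CC1(Cc2ccccc2)CC(S(=O)(=O)c2cccc(F)c2)=C(c2ccc(/C(N)=N\O)cc2)O1`: 28300 nM
- compound 2 `CC1(Cc2ccccc2)CC(S(=O)(=O)c2c(F)cccc2F)=C(c2ccc(/C(N)=N\O)cc2)O1`: 27000 nM

These two values lie within the scatter of each other, so compound 2 cannot be ranked against compound 1 on these numbers.

Next in the series is compound 3 `CC1(Cc2ccccc2)CC(S(=O)(=O)c2ccc(F)cc2F)=C(c2ccc(/C(N)=N\O)cc2)O1`. The change is 2,4-difluorophenyl in place of 2,6-difluorophenyl on a sulfonyl sulfur, which puts 2,4-difluorophenyl in place of 2,6-difluorophenyl on a sulfonyl sulfur. Within the data shown here, only one measured step bears on it: a 1.0-fold lower number from compound 1 to compound 2 (0.02 log units; within the scatter). That step was also an exchange of the group on the sulfonyl sulfur, and it stayed within the scatter. One step is thin evidence, but it gives no reason to expect a shift in either direction in this assay. The expected step, no larger than the scatter, is no change at the digits printed from compound 2 to compound 3 (within the scatter). Compound 3 is estimated at 27000 nM, with an expected range of 14000 nM to 50000 nM.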

Compound 3, half-maximal cytotoxic concentration: 41500 nM
Estimate against measurement, compound 3: 1.5-fold (0.19 log units) below, within the range that was stated.
By their numbers in this assay, from the lowest: compounds 2, 1 and 3 (each within the scatter of the next).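

In this assay the exchange of 2,6-difluorophenyl for 2,4-difluorophenyl gives a 1.5-fold higher number from compound 2 to compound 3 (0.19 log units; within the scatter) and the exchange of 3-fluorophenyl for 2,4-difluorophenyl gives a 1.5-fold higher number from compound 1 to compound 3 (0.17 log units; within the scatter) on the same sulfonyl sulfur. The three groups at this position, including two different arrangements of the two fluorines, therefore all stay within the scatter of each other in this assay and the earlier pair could not show this for a rearrangement of the same two fluorines. Nothing at hand explains these numbers. The compounds shown carry only fluorinated phenyl groups on the sulfonyl sulfur, so it stays open whether an unsubstituted phenyl, a phenyl bearing an amine or a carboxylic acid, or a longer alkyl chain would stay within the same scatter. As far as these compounds go, it is also open whether this holds once the rest of the core of compound 1 is altered.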